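The source may report more compounds than this note shows. Statements on the series, on what has been measured and on what is new or still open speak of the compounds shown alone.

For the measured compounds named here, compound 1 `COc1ccc(N(C)c2nc(C)nc3ccccc23)cc1OCCC[Se]C#N` is the weakest of the three measured members in a functional assay on A549 cells (Homo sapiens) for inhibition, read by MTT assay, with a stated time of 48 h; on this read-out lower numbers stand for stronger inhibition and higher numbers for weaker inhibition: compound 1 gives 382 nM, whereas compound 2 `C[Se]c1ccc(N(C)c2nc(C3CC3)nc3ccccc23)cc1` gives 13 nM and compound 3 `CN(c1ccc([Se]C#N)cc1)c1nc(C2CC2)nc2ccccc12` gives 12 nM. Compounds 2 and 3 differ from compound 1 both at the core and in the aryl substitution pattern, so their wide gap to compound 1 cannot be assigned to one change. Going by the values given here, the only measured single-point step is a 1.1-fold lower number from compound 2 to compound 3 (0.03 log units; within the scatter), which shows that cyano in place of methyl on a selenium leaves the number unchanged.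

Compound 4 `COc1ccc(N(C)c2nc(C)nc3ccccc23)cc1OCCN` is the next member to be measured. Relative to compound 1 the change is one nitrogen atom in place of a group of 4 heavy atoms (2 carbon, 1 nitrogen, 1 selenium; no ring), on a saturated chain carbon, two bonds along the chain from an oxygen on an aromatic ring. Among the compounds with values here, no measured step covers this: the step from compound 2 to compound 3 varies only the substituent on the selenium, whereas here the whole selenium-containing group is removed and amino enters. The expectation must rest on compound 1 alone and is weakly held. Compound 4 is expected to give roughly 800 nM, within a wide range of 250 nM to 3000 nM. The expected step is therefore a 2.1-fold higher number from compound 1 to compound 4 (0.32 log units; beyond the scatter), a modest move toward weaker inhibition that may well fall within the scatter.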

Compound 4, half-maximal inhibitory concentration: 122 nM
Compound 4: middle estimate off by 6.6-fold (0.82 log units), on the high side; measured number outside the range, below it.
By their numbers in this assay, from the lowest: compounds 3 and 2 (each within the scatter of the next); then compound 4; then compound 1.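

Amino in place of the selenium-containing group, on a saturated chain carbon two bonds along the chain from an oxygen on an aromatic ring, gives a 3.1-fold lower number from compound 1 to compound 4 (0.50 log units; beyond the scatter) in this assay and thus a modest move toward stronger inhibition. The earlier step varied only the substituent on the selenium, whereas this one shows that, on this chain, the number does not need selenium or the nitrile to stay in this range. No measurement at hand explains the direction of this step.

On these data alone, whether the step follows from the amino group itself or from the loss of the selenium-containing group remains open, and a hydroxyl or a dimethylamino group on the same saturated chain carbon would separate the two. A longer chain ending in amino would show whether the chain length matters here as well.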